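The source may report more compounds than this note shows. Statements on the series, on what has been measured and on what is new or still open speak of the compounds shown alone.

Measured compounds:
compound 1 `CN(C)CCn1cnnc1-c1cc(Oc2ccc(NC(=O)N/N=C/c3ccc(F)cc3Cl)cc2F)ccn1`, in a functional assay on U-87MG ATCC cells (Homo sapiens) for cytotoxicity, read by MTT assay, with a stated time of 72 h (on this read-out lower numbers stand for stronger inhibition and higher numbers for weaker inhibition), compound 1 gives 1210 nM
compound 2 `CN(C)CCn1cnnc1-c1cc(Oc2ccc(NC(=O)N/N=C/c3ccc(Cl)cc3)cc2F)ccn1`, compound 2 gives 1370 nM
compound 3 `CN(C)CCn1cnnc1-c1cc(Oc2ccc(NC(=O)N/N=C/c3cccc(Cl)c3Cl)cc2F)ccn1`, compound 3 gives 13200 nM

Compound 3 stands highest of the three numbers in this assay. Within the data shown here, the steps of an 11-fold higher number from compound 1 to compound 3 (1.04 log units; beyond the scatter) and a 9.6-fold higher number from compound 2 to compound 3 (0.98 log units; beyond the scatter) both lie beyond the scatter, whereas the step of a 1.1-fold higher number from compound 1 to compound 2 (0.05 log units; within the scatter) lies within it; compounds 1 and 2 are therefore indistinguishable here, and compound 3 is the one clearly weaker member.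

Compound 4 `CN(C)CCn1cnnc1-c1cc(Oc2ccc(NC(=O)N/N=C/c3ccc(O)cc3)cc2F)ccn1` differs from compound 3 in one place: 4-hydroxyphenyl in place of 2,3-dichlorophenyl on a carbon with a double bond to nitrogen.

Both steps leading into compound 3 bear on this change. Each of them exchanged a phenyl substituted like that of compound 1 or compound 2 for 2,3-dichlorophenyl and each raised the number beyond the scatter. Compound 4 moves away from 2,3-dichlorophenyl again, and 4-hydroxyphenyl shares its substitution pattern with the 4-chlorophenyl of compound 2. A downward step in this assay, roughly the reverse of a 9.6-fold higher number from compound 2 to compound 3 (0.98 log units; beyond the scatter), is therefore expected. Among the measured compounds shown here, no measured compound carries a hydroxyl on this ring, so the range is kept wide.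

For compound 4 the estimate is 2000 nM, with a range from 900 nM to 5000 nM, which is an expected step of a 6.6-fold lower number from compound 3 to compound 4 (0.82 log units; beyond the scatter).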

Compound 4, half-maximal inhibitory concentration: 7750 nM
Compound 4: the middle estimate sits 3.9-fold (0.59 log units) below what was measured, and the stated range ends below it.
By their numbers in this assay, from the lowest: compounds 1 and 2 (each within the scatter of the next); then compounds 4 and 3 (each within the scatter of the next).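

In this assay, the 4-hydroxyphenyl group on the carbon with a double bond to nitrogen does not match the 4-chlorophenyl of compound 2: hydroxy in place of chloro on an aromatic carbon gives a step beyond the scatter (a 5.7-fold higher number from compound 2 to compound 4 (0.75 log units; beyond the scatter)), so a single group on this ring in the same printed place does not by itself keep the number low. The step from the 2-chloro-4-fluorophenyl of compound 1 also lies beyond the scatter (a 6.4-fold higher number from compound 1 to compound 4 (0.81 log units; beyond the scatter)), whereas the step from the 2,3-dichlorophenyl of compound 3 lies within it (a 1.7-fold lower number from compound 3 to compound 4 (0.23 log units; within the scatter)), so the four compounds now form two pairs, with compounds 1 and 2 in one and compounds 3 and 4 in the other. No measurement on hand explains this split. The compounds shown leave open whether the step from compound 2 to compound 4 reflects the loss of chloro or the arrival of hydroxy, a question that unsubstituted phenyl, 4-methoxyphenyl or 4-aminophenyl at this place could help to separate. They also leave open whether this two-pair split holds on any cell line other than the one tested here.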